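From isopropylsulfonyl to methylsulfonyl, without a measured anchor

This account rests on a few compounds, and the source may have more. Where it says the series, first, only, none or still open, it means among the compounds named here.

Compound 1 `COCCN(C)S(=O)(=O)c1ccc(C)c(C#Cc2cc(Cl)ccc2OCC(=O)O)c1`: 0.007
Compound 2 `CC(C)S(=O)(=O)c1ccc(Cl)c(C#Cc2cc(Cl)ccc2OCC(=O)O)c1`: "not determined" (no result reported)
Compound 3 `Cc1ccc(S(=O)(=O)NC(C)C)cc1C#Cc1cc(Cl)ccc1OCC(=O)O`: 0.01

In an ADME assay on a cell-free system (plasma, Mus musculus) (on this read-out lower numbers stand for a smaller free fraction and higher numbers for a larger free fraction), compound 2 has no number to start from, its entry reading "not determined" (no result reported). Compound 4 `CS(=O)(=O)c1ccc(Cl)c(C#Cc2cc(Cl)ccc2OCC(=O)O)c1` differs from it by methyl in place of isopropyl on a sulfonyl sulfur. Going by the values given here, no measured step covers this change. The nearest one, a 1.4-fold higher number from compound 1 to compound 3 (0.15 log units; within the scatter), also falls on a sulfonyl sulfur and stays within the scatter. On that single step, no change beyond the scatter is expected, in either direction. The estimate therefore leans on compound 1 at 0.007 and compound 3 at 0.01. Compound 4 is expected at 0.012, with an estimated range of 0.005 to 0.03.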

Compound 4, unbound fraction: 0.025
Beside the measured number, compound 4's estimate is 2.1-fold (0.32 log units) below it, and the stated range covers the measured number.
By their numbers in this assay, from the lowest: compounds 1 and 3 (each within the scatter of the next); then compound 4.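

Going by these compounds alone, compound 2 has no reported result in this assay, so no step from it to compound 4 can be read. The effect of methyl in place of isopropyl on a sulfonyl sulfur stays open, and no evidence shown explains the value of compound 4.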